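The compounds below may be only part of what the source reports. "The series", "measured", "known", "first", "only" and "open" are said of these compounds alone.

Compound 3 `CC1CCCCN1c1ncc2[nH]nc(-c3ccc(N4CCN[C@H](C)C4)nc3)c2n1` gives 8.1 nM in an assay on Sf9 cells for inhibition of activin receptor type-1 (Homo sapiens), read by HTRF, with a stated time of 3 h, in the presence of a further agent that is not named here (on this read-out lower numbers stand for stronger inhibition and higher numbers for weaker inhibition), the second highest of the three measured numbers. Compound 2 `COCC(=O)N1C[C@@H](C)N(c2ncc3[nH]nc(-c4ccc(N5CCN[C@H](C)C5)nc4)c3n2)[C@@H](C)C1` gives 7.3 nM, within the scatter of compound 3, while compound 1 `C[C@@H]1CN(c2ccc(-c3n[nH]c4cnc(N5[C@H](C)COC[C@@H]5C)nc34)cn2)CCN1` gives 23 nM. Within the data shown here, the only measured step, a 2.8-fold lower number from compound 1 to compound 3 (0.45 log units; beyond the scatter), is the one that bears on compound 4 `C[C@@H]1CN(c2ccc(-c3n[nH]c4cnc(N5[C@H](C)CNC[C@@H]5C)nc34)cn2)CCN1`, which differs from compound 3 by 2,6-dimethylpiperazin-1-yl in place of 2-methylpiperidin-1-yl on an aromatic carbon. Among the measured compounds shown here, no measured step covers this exact change; the entering group resembles that of compound 1 more than the group it replaces, so the number is expected to move back toward that of compound 1 by a modest amount, if at all. Compound 4 is therefore expected to give 14 nM, with a range from 5 nM to 40 nM. The expected step is a 1.7-fold higher number from compound 3 to compound 4 (0.24 log units; within the scatter).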

Compound 4, half-maximal inhibitory concentration: 793 nM
Estimate against measurement, compound 4: 57-fold (1.75 log units) below; measured number outside the range, above it.
By their numbers in this assay, from the lowest: compounds 2 and 3 (each within the scatter of the next); then compound 1; then compound 4.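

In this assay, the position between two ring nitrogen atoms does not accept every six-membered ring: 2,6-dimethylpiperazin-1-yl gives a 98-fold higher number from compound 3 to compound 4 (1.99 log units; beyond the scatter) and a 34-fold higher number from compound 1 to compound 4 (1.54 log units; beyond the scatter). The free ring amine nitrogen carries the loss in these compounds, since hydrogen in place of (methoxymethyl)carbonyl gives a 110-fold higher number from compound 2 to compound 4 (2.04 log units; beyond the scatter). On these data alone, whether an acetyl or a methyl on that nitrogen would serve as well as (methoxymethyl)carbonyl stays open. Nothing available explains the loss.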